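The source may hold more compounds than are shown below. What is called first, only, known or untested is meant among the compounds shown, and "the series" means these compounds.

Measured so far:
- compound 1 `ClCc1ccccc1Cn1cnc2c(Cl)nc(Cl)nc21`: 3980 nM
- compound 2 `ClCc1ccccc1Cn1cnc2c(Cl)ncnc21`: 45700 nM
- compound 3 `ClCc1ccc(Cn2cnc3nc(Cl)nc(Cl)c32)cc1`: 6020 nM

In a functional assay on MDA-MB-231 cells (Homo sapiens) for cytotoxicity, read by sulforhodamine B assay, with a stated time of 48 h (a higher number here means that more compound is tolerated, a lower number that less compound is tolerated), compound 2 gives the highest number of the three, well beyond the scatter from both others; compound 3 stands nearest, compound 1 furthest. Among the compounds with values here, the one single-point step recorded is an 11-fold higher number from compound 1 to compound 2 (1.06 log units; beyond the scatter), so the chloro at that carbon is tied to a large shift in this assay.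

Compound 4 `Nc1nc(Cl)c2ncn(Cc3ccccc3CCl)c2n1` differs from compound 2 by amino in place of hydrogen on an aromatic carbon. Within the data shown here, no measured pair shows an amino entering at this carbon, so the only step that bears on it is the chloro-to-hydrogen step from compound 1 to compound 2, which says that this position is sensitive to substitution but not what an amino will do. Compound 4 is therefore expected to give a number lower than compound 2, with wide uncertainty: the estimate is 20000 nM, range 5000 nM to 60000 nM, that is an expected step of a 2.3-fold lower number from compound 2 to compound 4 (0.36 log units; beyond the scatter).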

Compound 4, concentration lethal to 50% of the cells: 63100 nM
Estimate against measurement, compound 4: 3.2-fold (0.50 log units) below; measured number above the stated range.
By their numbers in this assay, from the lowest: compounds 1 and 3 (each within the scatter of the next); then compounds 2 and 4 (each within the scatter of the next).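

In this assay, the amino group on this aromatic carbon between two ring nitrogen atoms cannot be told apart from hydrogen (a 1.4-fold higher number from compound 2 to compound 4 (0.14 log units; within the scatter)). Set against chloro at the same carbon, the amino group gives a large step (a 16-fold higher number from compound 1 to compound 4 (1.20 log units; beyond the scatter)), so among compounds 1, 2 and 4 the lower number goes only with chloro, while hydrogen and amino stay level. Nothing available explains why these two groups behave alike at this carbon.

Open, going by these compounds, is whether a methoxy or dimethylamino group at this carbon would stay level with hydrogen and amino or fall closer to chloro. Also open, on these data alone, is whether amino in place of chloro at this carbon would give a similar step on compound 3.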